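Working notes: substituent steps from compound 1

The source may hold more compounds than are shown below. What is called first, only, known or untested is meant among the compounds shown, and "the series" means these compounds.

Values in a functional assay on KB cells (Homo sapiens) for antiproliferative activity, read by sulforhodamine B assay, with a stated time of 3 days; on this read-out lower numbers stand for an effect already at smaller amounts and higher numbers for an effect only at larger amounts of compound:
- compound 1 `CCC1=C(O)c2c(oc(-c3ccccc3)cc2=O)C(CC)(CC)C1=O` gives > 236 uM (a limit)
- compound 2 `CCC1=C(O)c2c(oc(-c3ccc(CC(C)C)cc3)cc2=O)C(CC)(CC)C1=O` gives 29.3 uM
- compound 3 `CCC1=C(O)c2c(oc(-c3ccc(F)cc3)cc2=O)C(CC)(CC)C1=O` gives 33 uM
- compound 4 `CCC1=C(O)c2c(oc(-c3ccccc3C(F)(F)F)cc2=O)C(CC)(CC)C1=O` is not yet measured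

Compound 1 stands at the limit of > 236 uM in this assay, at which 1 of the 3 values shown sits. For compound 1 the reading > 236 uM is a limit of the assay and not a number. Any step starting from compound 1 therefore gives only a minimum size.

The change to compound 4 is trifluoromethyl in place of hydrogen on an aromatic carbon, ortho to a large group.

Within the data shown here, two measured steps bear on this change, as both also replace hydrogen on an aromatic carbon of compound 1. The first is an at least 8.0-fold lower number from compound 1 to compound 2 (0.90 log units; beyond the scatter), and the second is an at least 7.1-fold lower number from compound 1 to compound 3 (0.85 log units; beyond the scatter). Isobutyl and fluoro do not separate, as shown by a 1.1-fold higher number from compound 2 to compound 3 (0.05 log units; within the scatter). Neither compound 2 nor compound 3 carries its group ortho to a large group, so the transfer to compound 4 is uncertain and the range stays wide.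

A step of similar size is expected, toward a lower number and beyond the scatter, and it is estimated as an at least 5.2-fold lower number from compound 1 to compound 4 (0.71 log units; beyond the scatter). For compound 4 the estimated value is 45 uM, with an expected range of 15 uM to 190 uM.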

Compound 4, concentration for half-maximal effect: 45.6 uM
For compound 4 the middle estimate is 1.0-fold (0.01 log units) below the measured one; the range from low to high includes it.
By their numbers in this assay, from the lowest: compounds 2, 3 and 4 (each within the scatter of the next). At a limit, above all of these: compound 1.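

In this assay the place ortho to a large group, which compound 2 and compound 3 did not touch, also accepts a substituent, with trifluoromethyl in place of hydrogen giving an at least 5.1-fold lower number from compound 1 to compound 4 (0.71 log units; beyond the scatter) and a reading that can be stated as a number. A lower number is thus not tied to isobutyl or fluoro, nor to the place those two groups occupy, and compound 2, compound 3 and compound 4 each read within the scatter of the next. From the compounds shown here alone, the true size of the new step stays unknown, and it can be given only as a minimum because compound 1 sits at a limit of the assay and not at a number: the limit of > 236 uM in this assay, at which 1 of the 4 values shown sits.

Each of the three groups appears at one place only, so the effect of the group and the effect of its place on the aromatic ring cannot be told apart. Going by these compounds, it remains open how an amine, a carboxylic acid or a longer chain would read ortho to a large group, and whether trifluoromethyl would read the same at the place held by isobutyl and fluoro.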